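The source may hold more compounds than are shown below. What is called first, only, known or untested is meant among the compounds shown, and "the series" means these compounds.

Compound 1 `O=S(=O)(NCCNCc1cccc2ccccc12)c1cc(C(F)(F)F)cc(C(F)(F)F)c1` — in a functional assay on BE(2)-C cells (Homo sapiens) for inhibition, read by MTT assay, with a stated time of 72 h (on this read-out higher numbers stand for weaker inhibition of growth and lower numbers for stronger inhibition of growth), compound 1 gives 19000 nM.
Compound 2 `O=S(=O)(NCCCNCC1COc2ccccc2O1)c1cc(C(F)(F)F)cc(C(F)(F)F)c1` — in this assay compound 2 gives 2800 nM.

Compound 2 carries the lower of the two numbers, and its gap to compound 1 lies beyond the usual scatter. Compound 3 `COc1ccc(CNCCCNS(=O)(=O)c2cc(C(F)(F)F)cc(C(F)(F)F)c2)cc1` has not yet been measured. It differs from compound 2 in one place: 4-methoxyphenyl in place of 2,3-dihydro-1,4-benzodioxin-2-yl on a saturated chain carbon bound to an amine nitrogen. For the measured compounds named here, no step between two measured compounds exists here to set this change against. The step is expected to be small and to run toward a somewhat higher number, as a 1.4-fold higher number from compound 2 to compound 3 (0.15 log units; within the scatter). Compound 3 is estimated to give 4000 nM in this assay, within a range from 1500 nM to 12000 nM.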

Compound 3, concentration for 50% growth inhibition: 2800 nM
The estimate for compound 3 lay 1.4-fold (0.15 log units) above the measured number, and the stated range covers the measured number.
By their numbers in this assay, from the lowest: compounds 2 and 3 (each within the scatter of the next); then compound 1.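

In this assay, putting 4-methoxyphenyl in place of 2,3-dihydro-1,4-benzodioxin-2-yl on a saturated chain carbon bound to an amine nitrogen gives no change at the digits printed from compound 2 to compound 3 (within the scatter), so this place accepts either group. The six-membered non-aromatic ring with its 2 hetero atoms is therefore not needed for this level of growth inhibition in this pair. Nothing available explains why the two groups read alike. From the compounds shown here alone, whether a plain phenyl, a pyridyl or a cyclohexyl group would read the same here stays open. Going by these compounds, compound 1 differs from compound 2 in more than one place, so the separate contributions of its naphthalene group and its shorter chain also remain open.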